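Swapping the aryl on the sulfoxide for a pyridine

The compounds below may be only part of what the source reports. "The series", "measured", "known", "first", "only" and "open" are said of these compounds alone.

Measured compounds:
- compound 1 `CC(O)(C[S+]([O-])c1ccc(F)cc1F)C(=O)Nc1ccc([N+](=O)[O-])cc1C(F)(F)F`: 24400 nM
- compound 2 `CC(O)(C[S+]([O-])c1ccc(OC(F)(F)F)cc1)C(=O)Nc1ccc(C#N)c(C(F)(F)F)c1`: 36200 nM
- compound 3 `CC(O)(C[S+]([O-])c1ccc(C(F)(F)F)cn1)C(=O)Nc1ccc(C#N)c(C(F)(F)F)c1`: 95400 nM; > 100000 nM (2 entries)

Of the compounds shown here, three sharing one core have been tested in a functional assay on LNCaP cells (Homo sapiens) for antiproliferative activity; a lower number here means a stronger inhibitor, a higher number a weaker inhibitor. Compound 1 gives 24400 nM, the lowest of the two plain numbers, while compound 2 gives 36200 nM, a gap small enough to fall within the usual scatter, so the two cannot be ranked. Compound 3 was measured repeatedly: the several entries of compound 3 in this assay, 95400 nM; > 100000 nM (2 entries), and two of those entries are limits of the assay rather than numbers, which is its own statement about compound 3. Among the compounds with values here, no two measured compounds differ in only one place, so no single structural step has a measured size here.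

Compound 4 `CC(O)(C[S+]([O-])c1ccccn1)C(=O)Nc1ccc([N+](=O)[O-])cc1C(F)(F)F` has not yet been tested. It differs from compound 1 in one place: pyridin-2-yl in place of 2,4-difluorophenyl on a sulfur. In this assay, within the data shown here, the step is expected to move toward a weaker inhibitor, by a modest amount that may still stay close to the scatter, because compound 3, the only other compound carrying a nitrogen-containing ring on that sulfur, gives 95400 nM; > 100000 nM (2 entries). For compound 4 the estimate is 50000 nM, with a range from 15000 nM to 160000 nM, a step of a 2.0-fold higher number from compound 1 to compound 4 (0.31 log units; beyond the scatter) that is expected rather than known.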

Compound 4, half-maximal inhibitory concentration: > 100000 nM
Compound 4: only a limit was reported; the forecaster's own chance of this, stated with the estimate: 25%; middle value at least 2.0-fold (0.30 log units) from the limit.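

In this assay, the swap on this sulfur now has a measured size: pyridin-2-yl in place of 2,4-difluorophenyl gives an at least 4.0-fold higher number from compound 1 to compound 4 (0.61 log units; beyond the scatter), a step clearly beyond the scatter. On these data alone, compound 4 gives > 100000 nM, which is a limit of the assay and not a number, so the printed step is a minimum and its full size remains unknown. Compound 3 also carries a nitrogen-containing ring on that sulfur and differs from compound 4 in other places too, so it offers only loose support, but its read-out is similar in kind: the several entries of compound 3 in this assay, 95400 nM; > 100000 nM (2 entries)

The step changes two things at once, adding a ring nitrogen and removing both fluorines, and the compounds shown do not tell which of these matters. A plain phenyl or a pyridin-3-yl on the same sulfur, with the rest of compound 1 unchanged, would help to separate the two changes and show whether the position of the ring nitrogen matters.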